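The compounds below may be only part of what the source reports. "The series", "measured", "known", "first", "only" and "open" are said of these compounds alone.

Compound 1, `COC(=O)c1cncc(NS(=O)(=O)c2cc(Cl)ccc2OC)c1`: 65 nM
Compound 2, `COc1ccc(Br)cc1S(=O)(=O)Nc1cccnc1`: 43 nM
Compound 3, `COc1ccc(C(F)(F)F)cc1S(=O)(=O)Nc1cccnc1`: 183 nM

These three compounds were tested in an assay on isolated protein for inhibition of alkaline phosphatase, tissue-nonspecific isozyme (Homo sapiens); a higher number here means a weaker inhibitor, a lower number a stronger inhibitor. Compound 1 sits second highest of the three numbers: its value and that of compound 2 lie within the usual scatter of each other, while compound 3 gives a higher number than compound 1 by a margin beyond the scatter. Within the data shown here, the one single-point step among the measured compounds, a 4.3-fold higher number from compound 2 to compound 3 (0.63 log units; beyond the scatter), concerns the ring that carries the methoxy group, not the ring where compound 4 differs.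

Compound 4, `COc1ccc(Cl)cc1S(=O)(=O)Nc1cncc(-c2cccc(C)c2)c1`, arises from compound 1 by 3-methylphenyl in place of methoxycarbonyl on an aromatic carbon. Among the measured compounds shown here, no measured step touches this position or exchanges a group of this kind, so the measured data give no direction for this change. With nothing to point either way, compound 4 is expected to stay near compound 1 in this assay, with a wide range on both sides, at 60 nM (range 12 nM to 300 nM), which is estimated to mean a step of a 1.1-fold lower number from compound 1 to compound 4 (0.03 log units; within the scatter).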

Compound 4, half-maximal inhibitory concentration: 160 nM
Estimate against measurement, compound 4: 2.7-fold (0.43 log units) below; measured number inside the range.
By their numbers in this assay, from the lowest: compounds 2 and 1 (each within the scatter of the next); then compounds 4 and 3 (each within the scatter of the next).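

In this assay, this position on the ring with the nitrogen now has its first measured step: 3-methylphenyl in place of methoxycarbonyl gives a 2.5-fold higher number from compound 1 to compound 4 (0.39 log units; beyond the scatter). So the group here does affect the read-out, though the change is modest and compound 4 remains an inhibitor despite swapping the ester for a larger ring with no hydrogen-bond acceptors. Among these compounds, the single swap changes several features at once, and no available evidence explains the shift.

A carboxylic acid, an amine or a plain phenyl ring at this position could help separate the effect of losing the methoxycarbonyl from that of adding an aromatic ring. As far as these compounds go, the role of the methyl on the incoming ring also remains open, as does whether trifluoromethyl in place of bromo would have a similar effect with 3-methylphenyl present.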